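Pyridine amide replaces chloropyridine amide on shared core

The source may report more compounds than this note shows. Statements on the series, on what has been measured and on what is new or still open speak of the compounds shown alone.

Compound 1 `O=C(Nc1cc(C(F)(F)F)ccc1N1CCCCC1)c1ccccc1`: "not active" (no number reported)
Compound 2 `O=C(Nc1cc(C(F)(F)F)ccc1N1CCCC1)c1cccnc1Cl`: "not active" (no number reported)
Compound 3 `O=C(Nc1cc(C(F)(F)F)ccc1NC1CCCCC1)c1cccnc1`: 52300 nM

In a functional assay on NALM-6 cells (Homo sapiens) for cytotoxicity, read by MTT assay, with a stated time of 48 h (on this read-out lower numbers stand for stronger inhibition and higher numbers for weaker inhibition), compound 2 is recorded as "not active" (no number reported), with no number attached, and compound 1 stands the same way. Only compound 3 carries a number, 52300 nM, which is weak. Compound 4 `O=C(Nc1cc(C(F)(F)F)ccc1N1CCCC1)c1ccncc1` differs from compound 2 by pyridin-4-yl in place of 2-chloropyridin-3-yl on a carbonyl carbon. Going by the values given here, no measured pair shows what this change does, so no step size can be read from the data; with compound 2 at "not active" (no number reported) and compound 3 at 52300 nM, weak activity is the only picture, and in this assay nothing beyond the scatter is expected in either direction. Compound 4 is therefore estimated at about 60000 nM, with a range from 20000 nM to 200000 nM, and a real chance that the assay again reports no number.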

Compound 4, half-maximal inhibitory concentration: "not active" (no number reported)
No number was reported for compound 4; there is nothing to compare the estimate with.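

Compound 2 and compound 4 both come back without a number, so no step can be read between them. What replacing 2-chloropyridin-3-yl with pyridin-4-yl does to activity stays open, and no measurement shown offers an explanation.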